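This account rests on a few compounds, and the source may have more. Where it says the series, first, only, none or still open, it means among the compounds named here.

Among the measured compounds shown here, in a functional assay on CCRF-CEM cells (Homo sapiens) for inhibition, with a stated time of 72 h (a lower number here means a stronger inhibitor, a higher number a weaker inhibitor), compound 1 `OC[C@H]1O[C@@H](n2cnc3c(Cn4ccc5ccccc54)ncnc32)[C@H](O)[C@@H]1O` gives 3400 nM and stands lowest of the three numbers measured so far. Compound 2 `OC[C@H]1O[C@@H](n2cnc3c(COc4ccccn4)ncnc32)[C@H](O)[C@@H]1O` gives 16600 nM in this assay, and compound 3 `CSCc1ncnc2c1ncn2[C@@H]1O[C@H](CO)[C@@H](O)[C@H]1O` gives 15000 nM. Both changes away from compound 1 raised the number by a modest amount: a 4.9-fold higher number from compound 1 to compound 2 (0.69 log units; beyond the scatter) and a 4.4-fold higher number from compound 1 to compound 3 (0.64 log units; beyond the scatter), while a 1.1-fold lower number from compound 2 to compound 3 (0.04 log units; within the scatter), so the two smaller replacements sit together.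

Compound 4 `COCc1ncnc2c1ncn2[C@@H]1O[C@H](CO)[C@@H](O)[C@H]1O` is not yet measured. It differs from compound 1 in one place: methoxy in place of 1H-indol-1-yl on a saturated chain carbon bound to an aromatic carbon. For the measured compounds named here, of the measured steps, the one to compound 3 bears most closely on it, since methylsulfanyl and methoxy are each a two-heavy-atom group without a ring, and the step to compound 2 points the same way. Compound 4 is therefore expected to show a modestly higher number than compound 1 in this assay, roughly the size of a 4.1-fold higher number from compound 1 to compound 4 (0.61 log units; beyond the scatter). The estimate for compound 4 is 14000 nM, with a likely range from 6000 nM to 40000 nM.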

Compound 4, half-maximal inhibitory concentration: 6000 nM
Estimate against measurement, compound 4: 2.3-fold (0.37 log units) above, within the range that was stated.
By their numbers in this assay, from the lowest: compounds 1 and 4 (each within the scatter of the next); then compounds 3 and 2 (each within the scatter of the next).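

In this assay, the indole ring system proves dispensable at this position: methoxy on the saturated chain carbon bound to an aromatic carbon leaves the number within the scatter of the 1H-indol-1-yl group (a 1.8-fold higher number from compound 1 to compound 4 (0.25 log units; within the scatter)), so a small group without a ring can match it. Size alone does not settle the outcome, since the two small groups part beyond the scatter (a 2.5-fold lower number from compound 3 to compound 4 (0.40 log units; beyond the scatter)), and the atom linking the methyl group to this carbon therefore matters here. With the oxygen kept, the group on it matters too (a 2.8-fold lower number from compound 2 to compound 4 (0.44 log units; beyond the scatter)).

Nothing shown gives a reason for these differences. From the compounds shown here alone, whether an amine, a hydroxyl group or a longer chain such as ethoxy on this carbon would keep the number in the range of compound 4 remains open.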